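The compounds below may be only part of what the source reports. "The series", "measured", "known", "first", "only" and "open" are said of these compounds alone.

Compound 1 `CC[C@@H](Nc1c(C#N)c(-c2ccc(-c3ncccc3C)cc2)nc2cnccc12)C(N)=O` was measured in a physicochemical assay for lipophilicity, read by HPLC, at pH 7.5 (on this read-out lower numbers stand for lower lipophilicity and higher numbers for higher lipophilicity), where compound 1 gives 2. Two other compounds built on the same core were measured alongside it: compound 2 `CC(Nc1c(C#N)c(-c2ccc(Br)cc2)nc2cnccc12)C(N)=O` gives 2.1 in this assay, and compound 3 `CC[C@@H](Nc1c(C#N)c(-c2ccc(-c3cccc(C)c3F)cc2)nc2cnccc12)C(=O)O` gives 2.1. All three numbers sit within the usual scatter of one another, so none can be set apart from the others on this read-out.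

Compound 4 `CC[C@@H](Nc1c(C#N)c(-c2ccc(-c3ccc(Cl)cc3)cc2)nc2cnccc12)C(N)=O` has not yet been measured. It differs from compound 1 in one place: 4-chlorophenyl in place of 3-methylpyridin-2-yl on an aromatic carbon. For the measured compounds named here, no measured pair shows a step of this kind, so its size cannot be read from the data. An upward shift beyond the scatter is nonetheless expected in this assay. Compound 4 is estimated at 3.2, most likely between 2.6 and 3.8. The step this estimate implies, a number 1.20 log units higher from compound 1 to compound 4 (beyond the scatter), is expected to exceed the scatter.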

Compound 4, distribution coefficient: 3.1
Compound 4: middle estimate off by 0.10 log units, on the high side; the range from low to high includes it.
By their numbers in this assay, from the lowest: compounds 1, 2 and 3 (each within the scatter of the next); then compound 4.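

In this assay, for the compounds shown here, this position proves able to move the read-out: 4-chlorophenyl in place of 3-methylpyridin-2-yl gives a number 1.10 log units higher from compound 1 to compound 4 (beyond the scatter), whereas the earlier compounds could not be set apart. The two groups have the same heavy-atom count, yet the change swaps a ring nitrogen, the hydrogen-bond acceptor, for a carbon and adds a chlorine. Nothing measured here explains the step.

On these data alone, the ring nitrogen and the chlorine change together, so their separate shares remain unknown. As far as these compounds go, how an unsubstituted phenyl ring or a pyridine ring bearing chlorine would read at this position remains open.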